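A Sulfonamide Side Chain Replaces 4-Bromophenyl

The compounds below may be only part of what the source reports. "The series", "measured", "known", "first", "only" and "open" are said of these compounds alone.

Among the compounds with values here, in an ADME assay on HFF cells (Homo sapiens) for cytotoxicity, read by MTT assay, with a stated time of 72 h (on this read-out lower numbers stand for stronger inhibition and higher numbers for weaker inhibition), compound 1 `O=C1O[C@H]([C@@H](O)Cn2cc(-c3ccc(Br)cc3)nn2)C(OCc2ccccc2)=C1OCc1ccccc1` gives 5100 nM, the only true number available so far. Compound 2 `CCCCCc1ccc(-c2cn(C/C=C3\OC(=O)C(OCc4ccccc4)=C3OCc3ccccc3)nn2)cc1` gives > 100000 nM, which is a limit of the assay and not a number.

Compound 3 `O=C1O[C@H]([C@@H](O)Cn2cc(CNS(=O)(=O)c3ccc(F)cc3)nn2)C(OCc2ccccc2)=C1OCc1ccccc1` keeps the core of compound 1 but carries (((4-fluorophenyl)sulfonyl)amino)methyl in place of 4-bromophenyl on an aromatic carbon of a five-membered aromatic ring with 3 nitrogen ((((4-fluorophenyl)sulfonyl)amino)methyl in place of 4-bromophenyl on an aromatic carbon). Within the data shown here, no measured step shows what such an exchange does in this assay, so the expectation starts from compound 1 at 5100 nM and remains uncertain. The estimated change a 3.9-fold higher number from compound 1 to compound 3 (0.59 log units; beyond the scatter) is expected to be a moderate one toward weaker inhibition, beyond the usual scatter. Compound 3 is estimated at 20000 nM. Its expected range runs from 4000 nM to 100000 nM.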

Compound 3, half-maximal inhibitory concentration: 30 nM
Estimate against measurement, compound 3: 670-fold (2.82 log units) above; measured number outside the range, below it.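

In this assay, (((4-fluorophenyl)sulfonyl)amino)methyl in place of 4-bromophenyl on an aromatic carbon gives a 170-fold lower number from compound 1 to compound 3 (2.23 log units; beyond the scatter), a large move toward stronger inhibition with the rest of the core of compound 1 unchanged. Within the data shown here, this is the first step read at this position, and it shows that the read-out depends strongly on the group placed there, even though both groups carry one six-membered aromatic ring of carbon only. The entering group adds 1 hydrogen-bond donor and 2 hydrogen-bond acceptors, but nothing shown gives a reason for the step.

On these data alone, it remains open which part of the new side chain carries the step: the sulfonyl, the amide-like hydrogen on its nitrogen, the methyl link or the fluorine. As far as these compounds go, how a simple amine or a carboxylic acid on the same carbon would read also remains open.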